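The source may hold more compounds than are shown below. What is called first, only, known or untested is meant among the compounds shown, and "the series" means these compounds.

Working notes on the series. Within the data shown here, the three measured members share one core and differ only in the aromatic group on the sulfur of the ester side chain. Compound 1 `CCOc1cc2ncnc(Nc3ccc(F)c(Cl)c3)c2cc1OC(=O)CSc1cccnc1` carries pyridin-3-yl there and in a functional assay on NCI-H1975 cells (Homo sapiens) for inhibition, read by MTT assay, with a stated time of 72 h (a lower number here means a stronger inhibitor, a higher number a weaker inhibitor), compound 1 gives 3000 nM. Compound 2 `CCOc1cc2ncnc(Nc3ccc(F)c(Cl)c3)c2cc1OC(=O)CSc1nccn1C` carries 1-methyl-1H-imidazol-2-yl and in this assay compound 2 gives 6900 nM, a step of a 2.3-fold higher number from compound 1 to compound 2 (0.36 log units; beyond the scatter). Compound 3 `CCOc1cc2ncnc(Nc3ccc(F)c(Cl)c3)c2cc1OC(=O)CSc1nc2ccccc2n1C` carries 1-methyl-1H-benzimidazol-2-yl and in this assay compound 3 gives 9100 nM; this is the highest of the three numbers, with a 1.3-fold higher number from compound 2 to compound 3 (0.12 log units; within the scatter) and a 3.0-fold higher number from compound 1 to compound 3 (0.48 log units; beyond the scatter).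

Compound 4 `CCOc1cc2ncnc(Nc3ccc(F)c(Cl)c3)c2cc1OC(=O)CSc1nc2ccccc2s1` is not yet measured. Its change against compound 3 is 1,3-benzothiazol-2-yl in place of 1-methyl-1H-benzimidazol-2-yl on a sulfur. Among the measured compounds shown here, the steps that bear on it are those among compounds 1, 2 and 3, all changes of the aromatic group on the same sulfur: the fused ring added from compound 2 to compound 3 moved the number only within the scatter, and the larger swaps from compound 1 gave modest rises. For the measured compounds named here, no measured step exchanges a ring nitrogen bearing a methyl for a ring sulfur, so the direction of this step is uncertain and a small step in this assay, possibly none beyond the scatter, is expected. Compound 4 is therefore estimated at 9000 nM, between 3500 nM and 23000 nM, which means an expected step of a 1.0-fold lower number from compound 3 to compound 4 (0.00 log units; within the scatter).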

Compound 4, half-maximal inhibitory concentration: 9800 nM
Estimate against measurement, compound 4: 1.1-fold (0.04 log units) below, and the stated range covers the measured number.
By their numbers in this assay, from the lowest: compound 1; then compounds 2, 3 and 4 (each within the scatter of the next).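

In this assay, among these compounds, the exchange of 1-methyl-1H-benzimidazol-2-yl for 1,3-benzothiazol-2-yl on this sulfur, the first swap of a ring nitrogen bearing a methyl for a ring sulfur, gives a 1.1-fold higher number from compound 3 to compound 4 (0.03 log units; within the scatter), so this assay does not separate the two fused groups. Against the unfused 1-methyl-1H-imidazol-2-yl the step is a 1.4-fold higher number from compound 2 to compound 4 (0.15 log units; within the scatter), while against pyridin-3-yl it is a 3.3-fold higher number from compound 1 to compound 4 (0.51 log units; beyond the scatter), so with a third group of this kind only compound 1 stands apart, and compound 2, compound 3 and compound 4 stay within the scatter of one another. Nothing available gives a reason for these numbers.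

The compounds shown leave open whether this position responds at all to groups of a different kind, such as a pyridin-3-yl carrying a carboxylic acid or a dimethylamino group, or a plain butyl chain on the sulfur in place of an aromatic ring. Also open, from the compounds shown here alone, is whether an amide in place of the ester in the side chain would move the number further than any change of the group on the sulfur has so far.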